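The compounds below may be only part of what the source reports. "The series", "measured", "known", "first", "only" and "open" are said of these compounds alone.

Working notes on the series.

Compound 1 `CCCN(Cc1ccc(OCCN2C(=O)CCC2=O)c(C)c1)[C@@H](CC(=O)O)c1ccc(Cl)cc1` and compound 2 `Cc1cc(CN(CC2CC2)[C@@H](CC(=O)O)c2ccc(Cl)cc2)ccc1OCCN1C(=O)CCC1=O` are built on one core; compound 3 `CCCN(Cc1ccc(OCCn2c(=O)ccn(C)c2=O)c(OC)c1)C(CC(=O)O)c1ccc(Cl)cc1` and the not yet measured compound 4 `COc1cc(CN(CC2CC2)C(CC(=O)O)c2ccc(Cl)cc2)ccc1OCCn1c(=O)ccn(C)c1=O` are built on another. How the core of compound 3 differs from the core of compound 1 is not broken down here.

In a physicochemical assay for solubility, at pH 1.1 (on this read-out lower numbers stand for lower solubility and higher numbers for higher solubility), compound 1 gives 3000000 nM. In this assay compound 2 gives 3000000 nM, and compound 3 gives 3000000 nM. The step of no change at the digits printed from compound 1 to compound 2 (within the scatter) belongs to the change (cyclopropyl in place of ethyl on a saturated chain carbon bound to an amine nitrogen). Compound 3 stands level with compound 1 and with compound 2 at the digits reported, both gaps lying within the scatter.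

The change from compound 3 to compound 4 is cyclopropyl in place of ethyl on a saturated chain carbon bound to an amine nitrogen. The place is described in the same words as for the pair of compound 1 and compound 2, so it is taken as the same change, made now on the core of compound 3. Among the compounds shown it occurs two times in all.

For compound 4 the step of no change at the digits printed from compound 3 to compound 4 (within the scatter) is expected, resting on the step of no change at the digits printed from compound 1 to compound 2 (within the scatter) that the same change gave on the other core. Compound 4 is accordingly estimated at 3000000 nM in this assay, with 1500000 nM to 6000000 nM as the expected range. For the measured compounds named here, whether the second core carries the change as quietly as the first is what the measurement of compound 4 in this assay will show.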

Compound 4, solubility: 3000000 nM
For compound 4 middle estimate and measured number coincide at the digits printed, within the range that was stated.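

In this assay, cyclopropyl in place of ethyl on a saturated chain carbon bound to an amine nitrogen gives no change at the digits printed from compound 3 to compound 4 (within the scatter), which agrees with the no change at the digits printed from compound 1 to compound 2 (within the scatter) seen on the other core, so in both available pairs the change carries across without a step beyond the scatter. For the compounds shown here, this rests on only two pairs, in one read-out at a single pH, with compound 1, compound 2, compound 3 and compound 4 all level at the digits printed, and it does not show that the change would stay as quiet on a further core, in a compound with a different starting value or in any other assay. Nothing measured here bears on the reason for this result.

The compounds shown leave open whether any other group on that saturated chain carbon, such as a longer chain like butyl, a terminal amine or a carboxylic acid, would also stay level with ethyl in this assay. They also leave open how the individual differences between the two cores bear on this read-out, since no listed pair isolates any one of those differences.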